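The source may hold more compounds than are shown below. What is called first, only, known or untested is meant among the compounds shown, and "the series" means these compounds.

In a functional assay (muscle tissue) with Cavia porcellus as the target (a higher number here means that more compound is needed for the effect, a lower number that less compound is needed), compound 1 `COC(=O)C1=C(C)N=C(C)/C(=C(\O)OC)C1c1ccc(Cl)cc1` gives 8130 nM and compound 2 `COC(=O)C1=C(C)N=C(C)/C(=C(\O)OC)C1c1ccc(F)cc1` gives 129 nM on the shared core. Compound 3 `COC(=O)C1=C(C)N=C(C)/C(=C(\O)OC)C1c1cccc(N(C)C)c1` gives 891 nM in this assay and holds the second highest of the three numbers, lying between compound 2 and compound 1.

Compound 4 `COC(=O)C1=C(C)N=C(C)/C(=C(\O)OC)C1c1cccc(Br)c1` has bromo in place of dimethylamino on an aromatic carbon, meta to a large group bromo in place of dimethylamino on an aromatic carbon and has yet to be measured. For the measured compounds named here, no measured step covers this exchange. The closest evidence is a 63-fold lower number from compound 1 to compound 2 (1.80 log units; beyond the scatter) for fluoro in place of chloro, a large step beyond the scatter. It is a swap between halogens and involves no dimethylamino group, so it bears on the change only indirectly. The two halogen compounds also fall on either side of compound 3, which gives little guidance on direction. A sizeable step in this assay is expected, tentatively towards a lower number. The estimated change is an 8.9-fold lower number from compound 3 to compound 4 (0.95 log units; beyond the scatter) and remains uncertain. For compound 4 the estimated value is 100 nM with an expected range from 15 nM to 700 nM in this assay.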

Compound 4, half-maximal effective concentration: 1.29 nM
The estimate for compound 4 lay 78-fold (1.89 log units) above the measured number, and the stated range ends above it.
By their numbers in this assay, from the lowest: compound 4; then compound 2; then compound 3; then compound 1.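

Replacing dimethylamino with bromo on this aromatic carbon in this assay lowers the number sharply (a 690-fold lower number from compound 3 to compound 4 (2.84 log units; beyond the scatter)), so the group at this position can decide much of the value on the shared core. The 3-bromophenyl group also stands well apart from the other two halogen-bearing aryl groups (a 100-fold lower number from compound 2 to compound 4 (2.00 log units; beyond the scatter); a 6300-fold lower number from compound 1 to compound 4 (3.80 log units; beyond the scatter)), so carrying a halogen does not by itself give a low number, and compound 1 goes against any such reading. Nothing available here accounts for the size of these steps.

Compound 1 and compound 2 differ from compound 4 both in the halogen and in where it sits on the aromatic ring, so the two contributions cannot be separated. Going by these compounds, whether fluoro, chloro, nitro or methoxy on the same aromatic carbon would give a number as low as that of compound 4 remains open.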